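Trimming the Hydroxyethyl Side Chain: Expected Tolerance of Compound 3

The source may report more compounds than this note shows. Statements on the series, on what has been measured and on what is new or still open speak of the compounds shown alone.

The two measured compounds share one core. Compound 1 `COC(=O)[C@H](C)NC(=O)c1cnc2ccccc2c1Cl` carries a methyl on the saturated chain carbon bound to the amide-type nitrogen and the carbonyl carbon; in an ADME assay on CCRF-CEM cells (Homo sapiens) for cytotoxicity (a lower number here means that less compound is tolerated, a higher number that more compound is tolerated), compound 1 gives 81.3 uM. Compound 2 `COC(=O)[C@@H](NC(=O)c1cnc2ccccc2c1Cl)[C@@H](C)O` carries a 1-hydroxyethyl at that carbon. In this assay compound 2 reaches only a limit of the assay, > 100 uM. The step reads an at least 1.2-fold higher number from compound 1 to compound 2 (0.08 log units; that floor lies within the scatter), tied to the limit of > 100 uM in this assay, at which 1 of the 2 values shown sits. Compound 3 `COC(=O)[C@H](CO)NC(=O)c1cnc2ccccc2c1Cl` differs from compound 2 by hydrogen in place of methyl on a saturated chain carbon bound to an oxygen on a saturated carbon and a saturated chain carbon. Going by the values given here, the one measured step, from compound 1 to compound 2, is the only guide: it changed the same chain carbon, and its floor lies within the scatter. Compound 3 is therefore expected to show a step that the limit leaves unreadable from compound 2 to compound 3, no change beyond the scatter. Compound 3 is estimated at 110 uM, with a range from 55 uM to 250 uM.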

Compound 3, half-maximal toxic concentration: > 100 uM
Compound 3: only a limit was reported; the forecaster's own chance of this, stated with the estimate: 60%; the middle value does not contradict the limit.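

With hydroxy in place of hydrogen on this chain carbon, the side chain gives an at least 1.2-fold higher number from compound 1 to compound 3 (0.08 log units; that floor lies within the scatter), so a shorter hydroxy-bearing group than the 1-hydroxyethyl of compound 2 also leaves the floor of the step within the scatter. Compound 3 thus joins compound 2 at a limit of this assay rather than giving a number, and removing the methyl to turn 1-hydroxyethyl into hydroxymethyl brings no visible drop to a readable value. The step between the two cannot be read, and neither compound can be ranked against the other: the limit of > 100 uM in this assay, at which 2 of the 3 values shown sit.

Going by these compounds, how far either hydroxy-bearing compound truly lies from compound 1 remains unknown. On these data alone, whether an amine or a carboxylic acid on this chain carbon would stay at the limit or give a readable value also remains open.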